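Iodo to bromo in the growth inhibition series

This account rests on a few compounds, and the source may have more. Where it says the series, first, only, none or still open, it means among the compounds named here.

Measured so far in a functional assay on DU-145 cells (Homo sapiens) for inhibition, read by trypan blue exclusion, with a stated time of 96 h (a lower number here means a stronger inhibitor of growth, a higher number a weaker inhibitor of growth), are three compounds:
- compound 1 `COc1ccc(/C=C(/SCc2ccc(F)cc2)C(=O)c2ccc(Br)cc2)cc1` gives 50000 nM
- compound 2 `O=C(/C(=C\c1ccc(O)c([N+](=O)[O-])c1)S(=O)(=O)c1ccc(I)cc1)c1ccc(I)cc1` gives 25000 nM
- compound 3 `COc1cccc(OC)c1/C=C(\C(=O)c1ccc(Br)cc1)S(=O)(=O)c1ccc(Br)cc1` gives 10000 nM

Compound 2 lies within the scatter of compound 1, and its number is higher than that of compound 3 by a margin beyond the scatter. Compound 4 `O=C(/C(=C\c1ccc(O)c([N+](=O)[O-])c1)S(=O)(=O)c1ccc(I)cc1)c1ccc(Br)cc1` has not yet been measured in this assay and differs from compound 2 by bromo in place of iodo on an aromatic carbon in the (4-iodophenyl)carbonyl, which becomes (4-bromophenyl)carbonyl. This places bromo in place of iodo on an aromatic carbon, para to a large group. Going by the values given here, no measured pair shows this change alone, so the data give no size for it. Compound 1 and compound 3 also carry the (4-bromophenyl)carbonyl, but they differ from compound 2 elsewhere as well. No step beyond the scatter is therefore expected in this assay in either direction. The expected 1.3-fold lower number from compound 2 to compound 4 (0.10 log units; within the scatter) stays within the scatter. For compound 4 the estimate is 20000 nM with an expected range from 8000 nM to 50000 nM as a working figure.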

Compound 4, concentration for 50% growth inhibition: 25000 nM
Compound 4: middle estimate off by 1.3-fold (0.10 log units), on the low side; the range from low to high includes it.
By their numbers in this assay, from the lowest: compound 3; then compounds 2, 4 and 1 (each within the scatter of the next).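

In this assay, bromo in place of iodo on the aromatic carbon of the (4-iodophenyl)carbonyl gives no change at the digits printed from compound 2 to compound 4 (within the scatter). This pair gives the first size for the change alone. The earlier compounds shown here could not give it, as they differ from compound 2 elsewhere as well. On this core, at this carbon, para to a large group, the exchange of one halogen for the other leaves the growth inhibition reading unmoved, and no measurement available here offers an explanation for that.

Open, from the compounds shown here alone, is whether an amine or a carboxylic acid in place of the halogen on this carbon would give a step beyond the scatter. Also open, going by these compounds, is whether iodo in place of bromo would read the same on the core of compound 3.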